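Chain swap at the aromatic nitrogen: compound 1 toward compound 3

The source may hold more compounds than are shown below. What is called first, only, known or untested is meant among the compounds shown, and "the series" means these compounds.

Measured so far:
compound 1 `OCCn1nc(-c2cc3ccccc3[nH]2)nc1SCc1ccccc1` gives 12.1 ug/mL
compound 2 `CC(=O)N[C@@H]1[C@@H](OC(C)=O)[C@H](OC(C)=O)[C@@H](COC(C)=O)O[C@H]1n1nc(SCc2ccccc2)nc1-c1cc2ccccc2[nH]1` gives 16.6 ug/mL

In a functional assay on HepG2 cells (Homo sapiens) for antiproliferative activity, read by sulforhodamine B assay, with a stated time of 48 h (a lower number here means a stronger inhibitor, a higher number a weaker inhibitor), compound 1 holds the lower of the two numbers, but compound 2 sits within the scatter of it, so the two are not separated and no order is claimed. Within the data shown here, no pair of measured compounds differs in a single place, so no measured step is available to lean on.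

Compound 3 `C=CCn1nc(-c2cc3ccccc3[nH]2)nc1SCc1ccccc1` keeps the shared core of compound 1 and differs from it only at the chain on the aromatic nitrogen: vinyl in place of hydroxymethyl on a saturated chain carbon bound to an aromatic nitrogen. Nothing measured in the series tests this kind of exchange, so the expectation is a step of no clear direction and no larger than the scatter. For compound 3 the estimate is 12 ug/mL, with a range from 6 ug/mL to 25 ug/mL. This estimate amounts to an expected step of a 1.0-fold lower number from compound 1 to compound 3 (0.00 log units; within the scatter), essentially no change beyond the scatter.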

Compound 3, half-maximal inhibitory concentration: 15.9 ug/mL
Estimate against measurement, compound 3: 1.3-fold (0.12 log units) below, within the range that was stated.
By their numbers in this assay, from the lowest: compounds 1, 3 and 2 (each within the scatter of the next).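

This is the only single-place comparison shown in the series: in this assay, vinyl in place of hydroxymethyl on a saturated chain carbon bound to an aromatic nitrogen gives a 1.3-fold higher number from compound 1 to compound 3 (0.12 log units; within the scatter). The hydrogen-bond donor and acceptor counted on hydroxymethyl are absent from vinyl, yet the two numbers are not separated, so this exchange shows no need for either at this place in this assay. No measurement on hand bears on the reason for this outcome.

From the compounds shown here alone, whether the position stays as flat with other kinds of chain remains open: an amine or a carboxylic acid at the chain end, or a longer chain, would test this. One step within the scatter cannot establish a trend along this chain.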